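A few compounds are considered here, and "the series" means these few. Any claim that something is new, unique, unknown or untested is made for them only; others in the source may bear on it.

Working notes on the series. Three compounds sharing the same core have numbers in a functional assay on HL-60 cells (Homo sapiens) for antiproliferative activity, read by MTT assay, with a stated time of 48 h; a lower number here means a stronger inhibitor, a higher number a weaker inhibitor. Compound 1 `CCN(CC)C/C1=C/C[C@](C)(CCC=C(C)C)/C=C/[C@@H](OC(=O)C=C(C)C)[C@](C)(O)/C=C/C1=O` gives 140 nM and stands lowest of the three. Compound 3 `CC(C)=CCC[C@]1(C)/C=C/[C@@H](OC(=O)C=C(C)C)[C@](C)(O)/C=C/C(O)/C(C=O)=C\C1` gives 240 nM, which sits within the scatter of compound 1, so no order between them can be drawn. Compound 2 `CC(C)=CCC[C@]1(C)/C=C/[C@@H](OC(=O)C=C(C)C)[C@](C)(O)/C=C/C(=O)/C(C[Si](c2ccccc2)(c2ccccc2)C(C)(C)C)=C\C1` gives 14400 nM, a much higher number that lies well beyond the scatter of compound 1.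

Compound 4 `CCN(CC)C(=O)/C1=C/C[C@](C)(CCC=C(C)C)/C=C/[C@@H](OC(=O)C=C(C)C)[C@](C)(O)/C=C/C1=O` is the next compound for this assay. It differs from compound 1 in one place: diethylcarbamoyl in place of (diethylamino)methyl on a double-bonded ring carbon. The change keeps the same count of hydrogen-bond donors and acceptors but adds a double bond outside aromatic rings on the group at that ring carbon.

Going by the values given here, no measured pair isolates this kind of exchange, so the step rests on judgement alone. The expectation is a step from compound 1 to compound 4 of a 4.3-fold higher number from compound 1 to compound 4 (0.63 log units; beyond the scatter), toward a higher number, with wide uncertainty. Compound 4 is therefore estimated at 600 nM, within a range of 150 nM to 3000 nM.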

Compound 4, half-maximal inhibitory concentration: 9080 nM
Estimate against measurement, compound 4: 15-fold (1.18 log units) below; measured number above the stated range.
By their numbers in this assay, from the lowest: compounds 1 and 3 (each within the scatter of the next); then compounds 4 and 2 (each within the scatter of the next).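

In this assay, going by these compounds alone, the double-bonded ring carbon proves sensitive to the group it carries: diethylcarbamoyl in place of (diethylamino)methyl gives a 65-fold higher number from compound 1 to compound 4 (1.81 log units; beyond the scatter) in the first single-place exchange that can be read. The step is large even though both groups have the same count of hydrogen-bond donors and acceptors, so those counts alone do not track the number at this position. No measurement available here accounts for the size of this step.

On these data alone, whether the higher number follows from the carbonyl of the diethylcarbamoyl group or would recur with other groups at this ring carbon remains open. A (dimethylamino)methyl group, a morpholin-4-ylmethyl group or a carboxylic acid at the same carbon would show how far the result extends beyond this one pair.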